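The source may report more compounds than this note shows. Statements on the series, on what has been measured and on what is new or still open speak of the compounds shown alone.

In a physicochemical assay for lipophilicity, at pH 7.4 (on this read-out lower numbers stand for lower lipophilicity and higher numbers for higher lipophilicity), compound 1 `CC(C)CN(c1ccccc1F)S(=O)(=O)c1ccc2c(c1)C(O)CC(C1CCOCC1)O2` gives 3.39 and compound 2 `CC(C)CN(c1ccc(C#N)cc1)S(=O)(=O)c1ccc2c(c1)C(O)CC(C1CCOCC1)O2` gives 3.07 as the lower of the two numbers. Compound 3 `CC(C)CN(Cc1ccccc1C(F)(F)F)S(=O)(=O)c1ccc2c(c1)C(O)CC(C1CCOCC1)O2` has not been measured. Within the data shown here, it differs from compound 2 on the sulfonamide nitrogen by 2-(trifluoromethyl)benzyl in place of 4-cyanophenyl on a sulfonamide nitrogen as its one change. Among the measured compounds shown here, the only measured step at this nitrogen is a number 0.32 log units lower from compound 1 to compound 2 (beyond the scatter) and it is modest. With the 4-cyanophenyl of that step now leaving, a somewhat larger rise is expected in this assay here. For compound 3 the expected step is a number 0.63 log units higher from compound 2 to compound 3 (beyond the scatter) and it points upward. For compound 3 the estimated value is 3.7 with an expected range from 3.2 to 4.2 in this measurement.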

Compound 3, distribution coefficient: 4.23
Estimate against measurement, compound 3: 0.53 log units below, outside the stated range (above it).
By their numbers in this assay, from the lowest: compound 2; then compound 1; then compound 3.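

At the sulfonamide nitrogen, this assay spans far more than the earlier pair showed: 2-(trifluoromethyl)benzyl in place of 4-cyanophenyl gives a number 1.16 log units higher from compound 2 to compound 3 (beyond the scatter) and the same group in place of 2-fluorophenyl gives a number 0.84 log units higher from compound 1 to compound 3 (beyond the scatter) in this comparison. Compound 3 thus stands highest of the three, with both steps beyond the scatter. No evidence on hand accounts for the size of this rise. In these compounds, the benzyl carbon and the trifluoromethyl group enter together, so their separate contributions cannot be told apart. On these data alone, how a plain benzyl or a benzyl carrying an amine would read remains open.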